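This account rests on a few compounds, and the source may have more. Where it says the series, first, only, none or still open, it means among the compounds named here.

Measured so far:
compound 1 `CCCCCCCC/C=C\CCCCCCCCO[C@H]1O[C@H](CO)[C@@H](O)[C@H](O)[C@H]1NC(C)=O`: 4.8 uM in a functional assay on A-375 cells (Homo sapiens), read by thymidine incorporation; a higher number here means a weaker inhibitor, a lower number a stronger inhibitor
compound 2 `CCCCCCCC/C=C\CCCCCCCC(=O)N[C@H]1[C@@H](OCCCCCCCC)O[C@H](CO)[C@@H](O)[C@@H]1O`: 6 uM in this assay
compound 3 `CCCCCCCC/C=C\CCCCCCCC(=O)N[C@H]1[C@@H](OCCCCCCCC)O[C@H](CO)[C@@H](O)[C@@H]1OS(=O)(=O)O`: 16 uM in this assay

Compound 1 and compound 2 give numbers that lie within the usual scatter of each other; the difference between their two cores is not broken down here. Compound 2 and compound 3 share a core and differ in one place, (sulfo in place of hydrogen on an oxygen on a saturated carbon), and this change made a 2.7-fold higher number from compound 2 to compound 3 (0.43 log units; beyond the scatter). Compound 4 `CCCCCCCC/C=C\CCCCCCCCO[C@H]1O[C@H](COS(=O)(=O)O)[C@@H](O)[C@H](O)[C@H]1NC(C)=O` has not yet been measured. It differs from compound 1 by sulfo in place of hydrogen on an oxygen on a saturated carbon. This is the same kind of change, not the same: in compound 3 the saturated carbon's other neighbour is a saturated ring carbon, whereas in compound 4 it is a saturated chain carbon. Among the measured compounds shown here, a step of similar size, a 2.5-fold higher number from compound 1 to compound 4 (0.40 log units; beyond the scatter), is expected because a 2.7-fold higher number from compound 2 to compound 3 (0.43 log units; beyond the scatter) is the only comparable change seen here. Compound 4 is therefore estimated at 12 uM, within 5 uM to 30 uM.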

Compound 4, concentration for 50% inhibition: 0.6 uM
The estimate for compound 4 lay 20-fold (1.30 log units) above the measured number; measured number below the stated range.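

In this assay, the sulfo group brought an 8.0-fold lower number from compound 1 to compound 4 (0.90 log units; beyond the scatter), the opposite direction to the step seen on the other core. The same kind of change therefore cannot be carried from one core to the other in this series and be trusted to keep its direction or size: the same change on two cores in this assay, a 2.7-fold higher number (0.43 log units; beyond the scatter) from compound 2 to compound 3 and an 8.0-fold lower number (0.90 log units; beyond the scatter) from compound 1 to compound 4, 21-fold (1.33 log units) apart, beyond the scatter of two such steps. These two pairs differ both in their cores and in the saturated carbon that carries the sulfo group, a ring-bound carbon in one and a chain-bound carbon in the other, so they do not show which difference matters.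

Left open is what the change from hydroxymethyl to (sulfooxy)methyl would do on the core of compound 2. Among the compounds shown here, also open is whether a carboxylic acid or a phosphate in that place would give a step like the one to compound 4.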